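The source may hold more compounds than are shown below. What is called first, only, known or untested is meant among the compounds shown, and "the series" means these compounds.

Three chalcone-type compounds sharing the same core have been measured in a functional assay on HeLa cells (Homo sapiens) for inhibition, read by MTT assay, with a stated time of 48 h; on this read-out lower numbers stand for stronger inhibition and higher numbers for weaker inhibition. Compound 1 `O=C(/C=C/c1ccc(Cl)cc1)c1ccc[nH]1` gives 25000 nM in this assay. Compound 2 `O=C(/C=C/c1ccc(Br)cc1)c1ccc[nH]1` reaches only the limit of > 100000 nM in this assay, which is a limit rather than a number. Compound 3 `O=C(/C=C/c1ccc(Cl)cc1)c1ccco1` gives 38000 nM in this assay. Among the two numbers shown, compound 3 has the highest, with compound 1 nearest, and the step of a 1.5-fold higher number from compound 1 to compound 3 (0.18 log units; within the scatter) lies within the scatter. The step of an at least 4.0-fold higher number from compound 1 to compound 2 (0.60 log units; beyond the scatter) is the only one beyond the scatter, and it concerns a change on the halogen-bearing ring (the limit of > 100000 nM in this assay, at which 1 of the 3 values shown sits).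

Compound 4 `CN(C)c1ccc(/C=C/C(=O)c2ccco2)cc1` differs from compound 3 by dimethylamino in place of chloro on an aromatic carbon. Among the compounds with values here, no measured step exchanges a halogen for a dimethylamino group, so neither step gives a direct guide; the step from compound 1 to compound 2 shows only that a change at this position can weaken inhibition. Compound 4 is therefore expected to show a step of a 1.3-fold lower number from compound 3 to compound 4 (0.10 log units; within the scatter) in this assay, with no confident direction. Compound 4 is estimated at 30000 nM in this assay, within a range from 8000 nM to 120000 nM.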

Compound 4, half-maximal inhibitory concentration: 20000 nM
For compound 4 the middle estimate is 1.5-fold (0.18 log units) above the measured one; measured number inside the range.
By their numbers in this assay, from the lowest: compounds 4, 1 and 3 (each within the scatter of the next). At a limit, above all of these: compound 2.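

The exchange of chloro for dimethylamino, with 3 heavy atoms and 1 hydrogen-bond acceptor entering where 1 chlorine leaves, stays within the scatter in this assay: a 1.9-fold lower number from compound 3 to compound 4 (0.28 log units; within the scatter). Among the compounds bearing furan-2-yl on the carbonyl carbon, this position, para to a group of 9 heavy atoms, therefore accepts a larger group with a nitrogen in place of a halogen without a step beyond the scatter. Compound 2, which carries bromo in place of the chloro of compound 1, remains the only compound set apart, and its value is a limit and not a number: the limit of > 100000 nM in this assay, at which 1 of the 4 values shown sits.

The compounds shown leave open whether dimethylamino reads the same with 1H-pyrrol-2-yl on the carbonyl carbon, and whether bromo reads the same with furan-2-yl. They also leave open how a primary amine, a methoxy group or a carboxylic acid would read at this position.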